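A few compounds are considered here, and "the series" means these few. Any claim that something is new, unique, unknown or untested is made for them only; others in the source may bear on it.

Compound 1 `COc1ccc(C2CC(c3ccccc3)=NN2c2nc(-c3ccccc3)c(C#N)c(=O)n2C)cc1` gives 18000 nM in a functional assay on MCF7 cells (Homo sapiens) for antiproliferative activity, with a stated time of 72 h; on this read-out higher numbers stand for weaker inhibition and lower numbers for stronger inhibition.
Compound 2 `Cn1c(N2N=C(c3ccccc3)CC2c2ccccc2)nc(-c2ccc(Cl)cc2)c(C#N)c1=O` gives 34400 nM in this assay.
Compound 3 `COc1ccc(C2CC(c3ccccc3)=NN2c2nc(-c3ccc(Cl)cc3)c(C#N)c(=O)n2C)cc1` gives 52400 nM in this assay.

Compound 4 `Cn1c(N2N=C(c3ccc(Cl)cc3)CC2c2ccccc2)nc(-c2ccc(Cl)cc2)c(C#N)c1=O` has not yet been measured. It differs from compound 2 by one change, (chloro in place of hydrogen on an aromatic carbon), and the same change separates compound 1 from compound 3: chloro in place of hydrogen on an aromatic carbon. The two places are described in the same words, so the change is the same, although the difference between the two cores is not broken down here. Where the change has been measured, it went a 2.9-fold higher number from compound 1 to compound 3 (0.46 log units; beyond the scatter), a modest step and one beyond the scatter. The step of a 1.5-fold higher number from compound 2 to compound 3 (0.18 log units; within the scatter) shows how close compound 2 and compound 3 already sit.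

On that single precedent, the step from compound 2 to compound 4 is expected to be about a 2.5-fold higher number from compound 2 to compound 4 (0.39 log units; beyond the scatter) in this assay, resting on the measured step of a 2.9-fold higher number from compound 1 to compound 3 (0.46 log units; beyond the scatter) and on the value of compound 2, 34400 nM. Compound 4 is therefore estimated at 85000 nM, with a plausible range from 35000 nM to 200000 nM.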

Compound 4, half-maximal inhibitory concentration: 25300 nM
Beside the measured number, compound 4's estimate is 3.4-fold (0.53 log units) above it; the measured number lies below the stated range.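

In this assay the change from phenyl to 4-chlorophenyl gives a step that cannot be told apart from no change at all on this core (a 1.4-fold lower number from compound 2 to compound 4 (0.13 log units; within the scatter)). The same change therefore cannot simply be carried from one core to another in this series with its size intact, since the two measured cases disagree by more than repeat measurements would explain: the same change on two cores in this assay, a 2.9-fold higher number (0.46 log units; beyond the scatter) from compound 1 to compound 3 and a 1.4-fold lower number (0.13 log units; within the scatter) from compound 2 to compound 4, 4.0-fold (0.60 log units) apart, beyond the scatter of two such steps.
Among these compounds, this comparison rests on only two steps in a single read-out, so it does not show why the cores part ways, nor how chloro would behave on any further core.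

The compounds shown leave open whether a different group in that same place, such as bromo, an amine or a carboxylic acid, would also depend on the core in this way. They also leave open whether the two chloro steps would keep their difference in any read-out other than this assay.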